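Trifluoromethyl in place of nitro on the shared core

The source may hold more compounds than are shown below. What is called first, only, known or untested is meant among the compounds shown, and "the series" means these compounds.

For the measured compounds named here, the series so far holds compound 1 `O=[N+]([O-])c1ccccc1NC(CO)CO` and compound 2 `O=[N+]([O-])c1ccc(NC(CO)CO)c([N+](=O)[O-])c1`. In a functional assay on MDA-MB-468 cells (Homo sapiens) for cytotoxicity (on this read-out lower numbers stand for stronger inhibition and higher numbers for weaker inhibition), compound 1 gives only a limit, > 100000 nM. Compound 2 likewise returns only a limit, > 100000 nM. Going by the values given here, the single measured step, a step that the two limits leave unreadable from compound 1 to compound 2, therefore cannot be sized, and compound 2 stands at the limit together with every value recorded so far: the limit of > 100000 nM in this assay, at which 2 of the 2 values shown sit.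

Compound 3 `O=[N+]([O-])c1cc(C(F)(F)F)ccc1NC(CO)CO` is not yet measured. It differs from compound 2 by trifluoromethyl in place of nitro on an aromatic carbon. Among the compounds with values here, no measured step bears directly on this exchange: the only step recorded is unreadable, and no trifluoromethyl group appears among the measured compounds. The numbers shown thus give no direction, and nothing beyond the scatter can be read from them.

The expectation for compound 3 is a value that again sits at or near the limit, so the estimated step is a number no higher from compound 2 to compound 3 (the limit leaves the size open). For compound 3 the estimate in this assay is 100000 nM, with a range from 30000 nM to 300000 nM.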

Compound 3, half-maximal inhibitory concentration: > 100000 nM
Compound 3 gave a limit, no number (the forecaster's own chance of this, stated with the estimate: 80%); the middle value sits exactly at the limit.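

In this assay compound 3 gives > 100000 nM as a limit, not a number. The steps to compound 3 from compound 1 and from compound 2 therefore cannot be read, and the series stands at one point: the limit of > 100000 nM in this assay, at which 3 of the 3 values shown sit.

The compounds shown leave open whether any change on the shared core brings a value under the limit.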